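Chloro in Place of Tert-Butyl on the Shared Core

The source may report more compounds than this note shows. Statements on the series, on what has been measured and on what is new or still open speak of the compounds shown alone.

Compound 1 `COc1cc2ncnc(Nc3ccc(NC(=O)c4ccccc4OC)cc3)c2cc1OC`: in a functional assay on MCF7 cells (Homo sapiens) for inhibition, read by MTT assay (on this read-out higher numbers stand for weaker inhibition and lower numbers for stronger inhibition), compound 1 gives > 100000 nM, which is a limit of the assay and not a number.
Compound 2 `CCc1ccc(C(=O)Nc2ccc(Nc3ncnc4cc(OC)c(OC)cc34)cc2)cc1`: in this assay compound 2 gives 65000 nM.
Compound 3 `COc1cc2ncnc(Nc3ccc(NC(=O)c4ccc(C(C)(C)C)cc4)cc3)c2cc1OC`: in this assay compound 3 gives > 100000 nM, again a limit of the assay.

Compound 3 therefore stands at the edge of what this assay can report; the limit of > 100000 nM in this assay, at which 2 of the 3 values shown sit, shows that it shares this position with compound 1. Compound 4 `COc1cc2ncnc(Nc3ccc(NC(=O)c4ccc(Cl)cc4)cc3)c2cc1OC` keeps the shared core of compound 3 and differs in one group: chloro in place of tert-butyl on an aromatic carbon.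

For the measured compounds named here, two measured steps touch the same part of the molecule. The step of an at least 1.5-fold higher number from compound 2 to compound 3 (0.18 log units; that floor lies within the scatter) swaps one group on that aromatic carbon for another and is too small to read with confidence. The step that the two limits leave unreadable from compound 1 to compound 3 moves a group between two positions and cannot be sized at all. Neither step points in a clear direction, and all three values sit at very weak inhibition. For compound 4 the expected step of an at least 1.1-fold lower number from compound 3 to compound 4 (0.04 log units; that floor lies within the scatter) is therefore none beyond the scatter, with a real chance of another limit. The estimate for compound 4 in this assay is 90000 nM, expected between 30000 nM and 300000 nM.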

Compound 4, half-maximal inhibitory concentration: 30000 nM
For compound 4 the middle estimate is 3.0-fold (0.48 log units) above the measured one; the range from low to high includes it.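

Chloro in place of tert-butyl gives a change at this aromatic carbon that can be read in this assay: an at least 3.3-fold lower number from compound 3 to compound 4 (0.52 log units; beyond the scatter) is beyond the scatter, whereas the earlier step at the same carbon, from ethyl to tert-butyl, was not. Chloro also separates from ethyl at this carbon, with a 2.2-fold lower number from compound 2 to compound 4 (0.34 log units; beyond the scatter), so the group held here does shift the read-out even though inhibition stays weak, and the change from the other side chain of the series, an at least 3.3-fold lower number from compound 1 to compound 4 (0.52 log units; beyond the scatter), is beyond the scatter as well. Compounds 1 and 3 give limits and not numbers, so the steps that start from them have only a floor and their true size stays unknown: the limit of > 100000 nM in this assay, at which 2 of the 4 values shown sit.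

The compounds shown cannot separate what belongs to chloro itself from what any other replacement of tert-butyl or ethyl on this carbon might do, since bromo, methoxy and an amine do not appear there among them. From the compounds shown here alone, whether a carboxylic acid or a longer chain at this carbon would move the value further in either direction also stays open.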